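Shortening the alkyl chain on an acylguanidine histamine ligand

The source may report more compounds than this note shows. Statements on the series, on what has been measured and on what is new or still open speak of the compounds shown alone.

Compound 1, `CCCCCCNC(=O)/N=C(\N)Nc1cccc(-c2csc(N)n2)c1`, 692 nM
Compound 2, `N/C(=N\C(=O)NCc1ccccc1)NC1CCc2nc(N)sc2C1`, 513 nM
Compound 3, `Cc1nc(N)sc1CCCN/C(N)=N/C(=O)NC(C)c1ccc(Br)cc1`, 30.2 nM

Of the compounds shown here, three have been tested in an assay on membranes from Sf9 cells for displacement of a labelled ligand from histamine H2 receptor (Homo sapiens), read by scintillation counting, with a stated time of 60 min; on this read-out lower numbers stand for stronger inhibition and higher numbers for weaker inhibition. Compound 1 gives 692 nM, the highest number of the three. Compound 2 gives 513 nM, which lies within the usual scatter of compound 1, so the two cannot be told apart. Compound 3 gives 30.2 nM, a number well below that of compound 1, beyond the scatter, and it is built on a different core with a different chain, so its value does not speak directly to the change examined here.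

Compound 4, `CCCNC(=O)/N=C(\N)Nc1cccc(-c2csc(N)n2)c1`, keeps the core of compound 1 and differs in one place: hydrogen in place of propyl on a saturated chain carbon, three bonds along the chain from an amide-type nitrogen. For the measured compounds named here, no measured pair shows the effect of such a shortening on this scaffold. With nothing to lean on, a modest weakening or no change beyond the scatter is expected, since the chain loses part of its length. For compound 4 the expected value in this assay is 1200 nM, with a range of 400 nM to 4000 nM, a step from compound 1 to compound 4 of a 1.7-fold higher number from compound 1 to compound 4 (0.24 log units; within the scatter) that is anticipated rather than known.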

Compound 4, inhibition constant: 5250 nM
Compound 4: the middle estimate sits 4.4-fold (0.64 log units) below what was measured; the measured number lies above the stated range.
By their numbers in this assay, from the lowest: compound 3; then compounds 2 and 1 (each within the scatter of the next); then compound 4.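

In this assay, for the compounds shown here, the change from hexyl to propyl on the core of compound 1 gives a 7.6-fold higher number from compound 1 to compound 4 (0.88 log units; beyond the scatter) and is the first measured pair here that differs in only one place. It shows that the outer part of this chain is not idle: removing that stretch clearly weakens the reading, though this rests on a single pair on a single core. Nothing measured here explains why this step occurs.

The compounds shown leave open whether the number climbs evenly through pentyl and butyl or jumps at one particular length, and whether a longer chain such as octyl would lower it further. As far as these compounds go, it also remains open whether a hexyl chain ending in an amine or a phenyl ring would read like the plain hexyl chain.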